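Adding a Chloro to the Pendant Phenyl of Compound 1

The compounds below may be only part of what the source reports. "The series", "measured", "known", "first", "only" and "open" are said of these compounds alone.

The measured compounds:
compound 1 `Cc1cc(O)c(C(=O)/C=C/c2ccc(Cl)cc2)c(-c2ccccc2)c1C(=O)/C=C/c1ccc(Cl)cc1` in a functional assay on MDA-MB-231 cells (Homo sapiens) for cytotoxicity, read by MTT assay, with a stated time of 24 h (on this read-out higher numbers stand for weaker inhibition and lower numbers for stronger inhibition), gives 7900 nM;
compound 2 `Cc1cc(O)c(C(=O)/C=C/c2ccc(F)cc2)c(-c2ccc(Br)cc2)c1C(=O)/C=C/c1ccc(F)cc1` gives 22300 nM;
compound 3 `Cc1cc(O)c(C(=O)/C=C/c2ccc(F)cc2)c(-c2ccc(OCc3ccccc3)cc2)c1C(=O)/C=C/c1ccc(F)cc1` gives 15000 nM.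

Compound 1 stands with the lowest number of the three. Compound 3 is within the scatter of it, while compound 2 lies beyond the scatter at a higher number. Compound 4 `Cc1cc(O)c(C(=O)/C=C/c2ccc(Cl)cc2)c(-c2ccc(Cl)cc2)c1C(=O)/C=C/c1ccc(Cl)cc1` differs from compound 1 by chloro in place of hydrogen on an aromatic carbon. Among the measured compounds shown here, the only measured single step changes that same ring, a 1.5-fold lower number from compound 2 to compound 3 (0.17 log units; within the scatter), and it stayed within the scatter. For the measured compounds named here, compounds 2 and 3, both carrying a group on that ring, show higher numbers than compound 1, but they also differ elsewhere, so no direct step exists. Compound 4 is therefore expected to show at most a modest shift, a 1.2-fold higher number from compound 1 to compound 4 (0.08 log units; within the scatter), with an estimated 9500 nM (range 4000 nM to 25000 nM).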

Compound 4, half-maximal inhibitory concentration: 30000 nM
For compound 4 the middle estimate is 3.2-fold (0.50 log units) below the measured one; measured number outside the range, above it.
By their numbers in this assay, from the lowest: compounds 1, 3, 2 and 4 (each within the scatter of the next, the first and the last beyond it).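

Going from phenyl to 4-chlorophenyl gives a 3.8-fold higher number from compound 1 to compound 4 (0.58 log units; beyond the scatter) in this assay, so a single chloro at this place, para to a large group, is enough to weaken inhibition. Among the compounds shown here, this is the first direct comparison with the unsubstituted ring, and unlike the earlier step on this ring, it lies beyond the scatter. Nothing shown here accounts for this shift.

As far as these compounds go, whether other groups at this place would also raise the number remains open, as compounds 2 and 3 also differ from compound 1 elsewhere. An amine or a carboxylic acid on this ring could go either way.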